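A few compounds are considered here, and "the series" means these few. Any claim that something is new, unique, unknown or untested is made for them only; others in the source may bear on it.

Compound 1 `CC(C)c1ccc(C(C)C)c(C(=O)/C=C/C(=O)O)c1` is the better of the two measured compounds in a functional assay on LS174T cells (Homo sapiens) for inhibition, read by MTT assay, with a stated time of 72 h (a higher number here means a weaker inhibitor, a lower number a stronger inhibitor), where compound 1 gives 6230 nM. Going by the values given here, compound 2 `O=C(O)/C=C/C(=O)c1ccc(F)cc1` gives 33800 nM in the same assay, a gap that lies beyond the usual scatter; the two structures differ in several places, so no single step is drawn between them. Compound 3 `CCc1ccc(C(C)C)cc1C(=O)/C=C/C(=O)O` is not yet measured. It differs from compound 1 by hydrogen in place of methyl on a saturated chain carbon bound to an aromatic carbon and a saturated chain carbon. Among the compounds with values here, no step of this kind is measured, so the expectation rests on compound 1 alone: a small weakening, likely within the scatter, is expected for the step of a 1.3-fold higher number from compound 1 to compound 3 (0.11 log units; within the scatter). Compound 3 is estimated at 8000 nM, in a range from 3500 nM to 20000 nM.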

Compound 3, half-maximal inhibitory concentration: 5940 nM
The estimate for compound 3 lay 1.3-fold (0.13 log units) above the measured number; low and high end bracket the measured number.
By their numbers in this assay, from the lowest: compounds 3 and 1 (each within the scatter of the next); then compound 2.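

In this assay, going by these compounds alone, the change from isopropyl to ethyl gives a 1.0-fold lower number from compound 1 to compound 3 (0.02 log units; within the scatter) and is the first single-place step that can be read. At this saturated chain carbon, one methyl can go without a shift beyond the scatter. No evidence on the reason is at hand. From the compounds shown here alone, whether a longer chain, a cyclopropyl group or a hydroxyl group here would move the number stays open. So does whether the remaining isopropyl group on the core of compound 3 allows the same change.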